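Swapping 4-methoxyphenyl for 2-fluorophenyl in a tolerance test

The source may report more compounds than this note shows. Statements on the series, on what has been measured and on what is new or still open speak of the compounds shown alone.

Measured so far in an ADME assay on MDBK cells (Bos taurus) for cytotoxicity; a higher number here means that more compound is tolerated, a lower number that less compound is tolerated:
- Compound 1 `Cc1cccc(Cn2ccc3nc(-c4ccccc4)nc-3c2)c1` gives > 100000 nM as a limit
- Compound 2 `COc1ccc(Cn2ccc3nc(-c4ccccc4)nc-3c2)cc1` gives > 100000 nM as a limit

Compound 2 stands at > 100000 nM as a limit of the assay and not as a number. The only other result is also a limit. Among the measured compounds shown here, the one measured step is a step that the two limits leave unreadable from compound 1 to compound 2 and so offers no size to carry forward. Both compounds share the limit of > 100000 nM in this assay, at which 2 of the 2 values shown sit, and no finer ranking can be read from them.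

Compound 3 `Fc1ccccc1Cn1ccc2nc(-c3ccccc3)nc-2c1` carries 2-fluorophenyl in place of 4-methoxyphenyl on a saturated chain carbon bound to an aromatic nitrogen, and the full count of this change reads 2-fluorophenyl in place of 4-methoxyphenyl on a saturated chain carbon bound to an aromatic nitrogen here. A different group at this same place, in compound 1, also gave only a limit.

Resting on compound 2 at > 100000 nM as a limit, the expectation is no step beyond the usual scatter in this assay and no particular direction. The estimated step is a number no higher from compound 2 to compound 3 (the limit leaves the size open) and it is expected to stay small. For compound 3 the estimated value is 100000 nM with an expected range from 60000 nM to 200000 nM as the estimate stands.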

Compound 3, half-maximal cytotoxic concentration: > 100000 nM
Compound 3: only a limit was reported (the forecaster's own chance of this, stated with the estimate: 85%); the middle value sits exactly at the limit.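

In this assay compound 3 gives > 100000 nM, which is a limit and not a number, so the steps among compound 1, compound 2 and compound 3 cannot be read, and all three share one result: the limit of > 100000 nM in this assay, at which 3 of the 3 values shown sit.

The compounds shown leave open how much of each compound the cells would tolerate past this limit, and whether the 3-methylphenyl, 4-methoxyphenyl and 2-fluorophenyl groups differ at all here.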